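Phenyl for butyl on a selenocyanate carbamate

This account rests on a few compounds, and the source may have more. Where it says the series, first, only, none or still open, it means among the compounds named here.

Compound 1 `CCCCOC(=O)Nc1ccc([Se]C#N)cc1` was tested in a functional assay on MCF7 cells (Homo sapiens) for cytotoxicity, read by MTT assay, with a stated time of 72 h (on this read-out higher numbers stand for weaker inhibition of growth and lower numbers for stronger inhibition of growth), where compound 1 gives 20200 nM. Among the compounds with values here, the only other measured compound, compound 2 `O=C(Nc1ccc([Se][Se]c2ccc(NC(=O)Oc3ccc(F)cc3)cc2)cc1)Oc1ccc(F)cc1`, gives 33700 nM in this assay, and the two values lie within the scatter of each other, so neither can be called more active. Compound 3 `N#C[Se]c1ccc(NC(=O)Oc2ccccc2)cc1` differs from compound 1 by phenyl in place of butyl on an oxygen next to a carbonyl group. Within the data shown here, no step of this kind has been measured here, so only a small shift, if any beyond the scatter, is expected for the step of a 1.3-fold lower number from compound 1 to compound 3 (0.13 log units; within the scatter). Compound 3 is therefore estimated at 15000 nM, with a range from 5000 nM to 45000 nM.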

Compound 3, concentration for total growth inhibition: 35900 nM
For compound 3 the middle estimate is 2.4-fold (0.38 log units) below the measured one; the measured number falls inside the stated range.
By their numbers in this assay, from the lowest: compounds 1, 2 and 3 (each within the scatter of the next).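

In this assay, phenyl in place of butyl on an oxygen next to a carbonyl group now has a measured step, a 1.8-fold higher number from compound 1 to compound 3 (0.25 log units; within the scatter). At this place, then, a six-membered aromatic ring of carbon only and a butyl chain cannot be told apart by this read-out. Nothing measured here bears on why.

From the compounds shown here alone, whether this position responds to any change remains open, since only these two groups have been compared there. A longer chain, an amine or a carboxylic acid at the same place could still give a step beyond the scatter.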